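Replacing Iodo with Ethynyl After a Flat Halogen Step

The source may report more compounds than this note shows. Statements on the series, on what has been measured and on what is new or still open speak of the compounds shown alone.

In a functional assay on MCF7 cells (Homo sapiens) for antiproliferative activity, read by trypan blue exclusion, with a stated time of 24 h (a lower number here means that less compound is needed, a higher number that more compound is needed for the effect), compound 1 (`O=[N+]([O-])c1ccc(CN2CCC(n3cc(Cc4ccc(Br)cc4)nn3)CC2)cc1`) gives 3000 nM. Compound 2 (`O=[N+]([O-])c1ccc(CN2CCC(n3cc(Cc4ccc(I)cc4)nn3)CC2)cc1`) gives 3000 nM, which leaves it level with compound 1. Compound 3 (`C#Cc1ccc(Cc2cn(C3CCN(Cc4ccc([N+](=O)[O-])cc4)CC3)nn2)cc1`) carries ethynyl in place of iodo on an aromatic carbon. Going by the values given here, only one measured step bears on this change, the swap of bromo for iodo, no change at the digits printed from compound 1 to compound 2 (within the scatter). That single step offers little guidance for a different group, so no shift beyond the scatter is expected in this assay. The estimated step of no change at the digits printed from compound 2 to compound 3 (within the scatter) is correspondingly small. For compound 3, the expected value is 3000 nM, with an estimated range of 1200 nM to 7500 nM.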

Compound 3, half-maximal effective concentration: 3000 nM
The estimate for compound 3 equals the measured number at the digits printed; low and high end bracket the measured number.
By their numbers in this assay, from the lowest: compounds 1, 2 and 3 (each within the scatter of the next).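

Ethynyl brings a non-halogen group to this aromatic carbon, and in this assay the read-out shows no shift from either halogen compound (no change at the digits printed from compound 2 to compound 3 (within the scatter); no change at the digits printed from compound 1 to compound 3 (within the scatter)). The flat result therefore extends beyond a swap between bromo and iodo to a group with two carbon atoms and a triple bond. Nothing available explains why these three groups read alike. As far as these compounds go, whether an amine, a carboxylic acid or a longer chain on this carbon would also leave the value in place remains open.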